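Quaternary ammonium tail swap on a fibrosis reporter series

The source may report more compounds than this note shows. Statements on the series, on what has been measured and on what is new or still open speak of the compounds shown alone.

Measured so far:
- compound 1, `CN(C)c1ccc2c(=O)c(C(=O)Nc3cc(F)cc(F)c3)cn(-c3ccc(Cl)c(OCCCCCCC[N+]45CCN(CC4)CC5)c3)c2n1`: 18.7%
- compound 2, `CC[N+]1(CCCCCCCOc2cc(-n3cc(C(=O)Nc4cc(F)cc(F)c4)c(=O)c4ccc(N(C)C)nc43)ccc2Cl)CCCCC1`: "not active" (no number reported)

In an assay on LX2 cells for inhibition of COL1A1 promoter (Homo sapiens), read by a luciferase reporter, with a stated time of 24 h, tested at 50 uM (on this read-out lower numbers stand for a weaker effect and higher numbers for a stronger effect at the one concentration tested), compound 1 gives 18.7%. In this assay compound 2 is reported only as "not active" (no number reported), with no number attached, so compound 2 stands at the weak end of what has been seen and cannot be placed more finely than that.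

Compound 3, `CN1CC[N+](C)(CCCCCCCOc2cc(-n3cc(C(=O)Nc4cc(F)cc(F)c4)c(=O)c4ccc(N(C)C)nc43)ccc2Cl)CC1`, has not been measured. It differs from compound 2 by a group of 8 heavy atoms (6 carbon, 2 nitrogen; one six-membered non-aromatic ring with 2 hetero atoms) in place of a group of 8 heavy atoms (7 carbon, 1 nitrogen; one six-membered non-aromatic ring with 1 hetero atom), on a saturated chain carbon, seven bonds along the chain from an oxygen on an aromatic ring. Going by the values given here, no measured pair shows the effect of this kind of exchange, so the step from compound 2 to compound 3 cannot be read from the data; the expectation is a small change, if any, most likely staying within the usual scatter, with at most a modest move toward a stronger effect.

On that basis, compound 3 is expected to give about 10% in this assay, with a plausible range from 0% to 25%.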

Compound 3, a percentage reported as inhibition, at one concentration (the size of the read-out at that concentration, not a potency): 45.2%
Compound 3: middle estimate off by 35.2 percentage points, on the low side; measured number outside the range, above it.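

In this assay, the group on the saturated chain carbon, seven bonds along the chain from an oxygen on an aromatic ring, is clearly not a silent spot: replacing the two-ring group of compound 1 with the single-ring group gives a number 26.5 percentage points higher from compound 1 to compound 3 (beyond the scatter) on the same core. Going by these compounds alone, compound 2 is reported as "not active" (no number reported) and so offers no step to read, but its ring with 1 hetero atom and the ring with 2 hetero atoms in compound 3 have the same size and net charge, and only compound 3 carries a measured effect. No measurement here gives a reason for either difference.

As far as these compounds go, it remains open whether the gain comes from the second ring nitrogen or its methyl group, which a morpholine ring with oxygen at that spot could help separate. A shorter or longer chain could also change the result.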